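Amino-substituent variants on the shared core: acyl amide step

The source may hold more compounds than are shown below. What is called first, only, known or untested is meant among the compounds shown, and "the series" means these compounds.

Three compounds of the series have been run in a functional assay on MCF7 cells (Homo sapiens) for cytotoxicity, read by sulforhodamine B assay, with a stated time of 48 h; a higher number here means a weaker inhibitor, a lower number a stronger inhibitor. Compound 1 `CC1(C)CC(=O)C2=C(C1)N(c1ccc(S(N)(=O)=O)cc1)C(N)=C(C#N)C2c1ccc(F)cc1` gives 71800 nM. Compound 2 `CCO/C=N/C1=C(C#N)C(c2ccc(F)cc2)C2=C(CC(C)(C)CC2=O)N1c1ccc(S(N)(=O)=O)cc1` gives 67300 nM. Compound 3 `CC1(C)CC(=O)C2=C(C1)N(c1ccc(S(N)(=O)=O)cc1)C(N)=C(C(N)=O)C2c1ccc(F)cc1` gives 75200 nM. The numbers of compound 2, compound 1 and compound 3 all lie within the scatter of one another; the step of a 1.1-fold lower number from compound 1 to compound 2 (0.03 log units; within the scatter) and the step of a 1.0-fold higher number from compound 1 to compound 3 (0.02 log units; within the scatter) confirm that neither exchange on the double-bonded ring carbon moved the read-out.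

Compound 4 `CC(=O)CC(=O)NC1=C(C#N)C(c2ccc(F)cc2)C2=C(CC(C)(C)CC2=O)N1c1ccc(S(N)(=O)=O)cc1` is the next member. Relative to compound 2 the change is a group of 7 heavy atoms (4 carbon, 1 nitrogen, 2 oxygen; no ring) in place of a group of 5 heavy atoms (3 carbon, 1 nitrogen, 1 oxygen; no ring), on a double-bonded ring carbon. Within the data shown here, the steps that bear on it are the two just named, both at or near the same position of the core and both within the scatter. Among the measured compounds shown here, no measured step here points in any direction beyond the scatter, so the expected step of a 1.0-fold higher number from compound 2 to compound 4 (0.02 log units; within the scatter) in this assay is none beyond the scatter. Compound 4 is therefore estimated at 70000 nM, with an expected range from 35000 nM to 140000 nM.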

Compound 4, half-maximal inhibitory concentration: > 100000 nM
Compound 4: a limit, no number; the forecaster's own chance of this, stated with the estimate: 10%; at least 1.4-fold (0.15 log units) between middle value and limit.
By their numbers in this assay, from the lowest: compounds 2, 1 and 3 (each within the scatter of the next). At a limit, above all of these: compound 4.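

Among these compounds, compound 4, with ((2-oxopropyl)carbonyl)amino on the double-bonded ring carbon, is the first member of the series whose result in this assay is a limit and not a number: the limit of > 100000 nM in this assay, at which 1 of the 4 values shown sits. The steps read as an at least 1.4-fold higher number from compound 2 to compound 4 (0.17 log units; that floor lies within the scatter) and an at least 1.3-fold higher number from compound 1 to compound 4 (0.14 log units; that floor lies within the scatter), so neither floor shows a change beyond the scatter. From the compounds shown here alone, at this position, (2-oxopropyl)carbonyl on the amine nitrogen therefore gives no lower number than the free amine of compound 1, and the true size of the step remains unknown.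

The compounds shown leave open whether a smaller acyl group such as acetyl would return a measurable number in this assay. They also leave open how a longer acyl chain or a benzoyl group on the same amine nitrogen would read out.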